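Methoxy in Place of Fluoro: Estimating a Cytotoxicity Value

The compounds below may be only part of what the source reports. "The series", "measured", "known", "first", "only" and "open" are said of these compounds alone.

compound 1 `Cc1ccc(-c2ccnc(Nc3ccc(F)cc3)c2)cc1`: 146000 nM
compound 2 `COc1ccc(Nc2cc(-c3cccc(C(F)(F)F)c3)ccn2)cc1`: 140000 nM
compound 3 `COc1ccc(Nc2cc(-c3ccc(C)cc3)ccn2)cc1`: not yet measured

In a functional assay on HeLa cells (Homo sapiens) for cytotoxicity, read by MTT assay, with a stated time of 72 h (a lower number here means a stronger inhibitor, a higher number a weaker inhibitor), compound 1 gives 146000 nM, and compound 2 gives 140000 nM. These two numbers lie within the usual scatter of each other, so compound 1 stands level with compound 2, and neither can be ranked over the other.

Compound 3 differs from compound 1 in one place: methoxy in place of fluoro on an aromatic carbon, para to a large group (methoxy in place of fluoro on an aromatic carbon). Going by the values given here, no two measured compounds differ in just one place, so the data show no direct example of how large such a change can be. The only hint is thin. Fluoro is present in compound 1 at 146000 nM, and methoxy is present in compound 2 at 140000 nM. On that basis, no step beyond the scatter is expected in this assay, in either direction. The estimated change is a 1.1-fold lower number from compound 1 to compound 3 (0.05 log units; within the scatter). For compound 3 the estimated value is 130000 nM, with an expected range from 50000 nM to 300000 nM.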

Compound 3, half-maximal inhibitory concentration: 43000 nM
Beside the measured number, compound 3's estimate is 3.0-fold (0.48 log units) above it, outside the stated range (below it).
By their numbers in this assay, from the lowest: compound 3; then compounds 2 and 1 (each within the scatter of the next).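

In this assay, replacing fluoro with methoxy on an aromatic carbon, para to a large group, gives a 3.4-fold lower number from compound 1 to compound 3 (0.53 log units; beyond the scatter). Going by these compounds alone, this is the first direct comparison, and although the step is modest, it lies beyond the scatter, so this position is not indifferent to the group it carries. The two groups differ in what can be counted: methoxy has two heavy atoms and one hydrogen-bond acceptor, while fluoro has one heavy atom and no hydrogen-bond acceptor, but nothing available here shows which difference, if either, accounts for the step.

A single pair cannot show whether the lower number is particular to methoxy or whether other groups at the same place, such as an amine, a hydroxyl or a longer ethoxy chain, would move it as far or further. It also leaves open whether the same exchange would give a similar step on the trifluoromethyl-bearing core of compound 2, whose fluoro counterpart is not among the compounds shown.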